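Piperazine for Piperidine on the Amide Chain

The source may report more compounds than this note shows. Statements on the series, on what has been measured and on what is new or still open speak of the compounds shown alone.

Compound 1 `COc1ccc(S(=O)(=O)N(CC(N)=O)c2ccc(N(CC(N)=O)S(=O)(=O)c3ccc(NC(=O)CN4CCC(C)CC4)cc3)c3ccccc23)cc1` and compound 2 `COc1ccc(S(=O)(=O)N(CC(N)=O)c2ccc(N(CC(N)=O)S(=O)(=O)c3ccc(NC(=O)CCN4CCC(C)CC4)cc3)c3ccccc23)cc1` share one core and differ only in the saturated chain that carries the 4-methylpiperidin-1-yl group. In a functional assay on cells (Peritoneal macrophage, Mus musculus) for cytotoxicity, with a stated time of 24 h (on this read-out lower numbers stand for higher toxicity in this test and higher numbers for lower toxicity in this test), compound 1 reaches only a limit of the test, > 50000 nM. In this assay compound 2 likewise reaches only a limit, > 100000 nM. The size of a step that the two limits leave unreadable from compound 1 to compound 2 is therefore unreadable. Compound 3 `COc1ccc(S(=O)(=O)N(CC(N)=O)c2ccc(N(CC(N)=O)S(=O)(=O)c3ccc(NC(=O)CCN4CCN(C(C)C)CC4)cc3)c3ccccc23)cc1` carries 4-isopropylpiperazin-1-yl in place of 4-methylpiperidin-1-yl on a saturated chain carbon, two bonds along the chain from a carbonyl carbon. Going by the values given here, no measured step bears on this change and both known values sit at limits, so no step beyond the scatter is expected, the estimated step being a number no higher from compound 2 to compound 3 (the limit leaves the size open). Compound 3 is thus estimated at 100000 nM in this assay, within 50000 nM to 300000 nM.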

Compound 3, half-maximal cytotoxic concentration: > 100000 nM
Compound 3 ended at the assay's limit; the forecaster's own chance of this, stated with the estimate: 85%; the middle value lies on the limit itself.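

Compound 3 gives > 100000 nM in this assay, which is a limit of the test. Going by these compounds alone, no step among compound 1, compound 2 and compound 3 can be read. Still open, from the compounds shown here alone, is where the half-maximal cytotoxic concentration of each compound lies, and whether 4-isopropylpiperazin-1-yl in place of 4-methylpiperidin-1-yl shifts it.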